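Oxygen to Sulfur on a Carbonyl Carbon

The source may report more compounds than this note shows. Statements on the series, on what has been measured and on what is new or still open speak of the compounds shown alone.

For the measured compounds named here, compound 1, `Cc1nc(S(C)(=O)=O)ccc1Oc1ncnc(OC2CCN(C(=O)OC3CCC3)CC2)c1F`, is tested in a functional assay on isolated protein for inhibition of Glucose-dependent insulinotropic receptor (Rattus norvegicus), read by HTRF and cAMP accumulation (a lower number here means a smaller maximal response, a higher number a larger maximal response), and gives 81%, the highest of the two numbers measured so far. The nearest is compound 2, `Cc1nc(S(C)(=O)=O)ccc1Oc1ncnc(OC2CCN(C(=O)OC3COC3)CC2)c1F`, which in this assay gives 66%. Going by the values given here, the single measured step, a number 15 percentage points lower from compound 1 to compound 2 (beyond the scatter), lies beyond the scatter and is modest in size. Compound 3, `Cc1nc(S(C)(=O)=O)ccc1Oc1ncnc(OC2CCN(C(=O)SC3CCC3)CC2)c1F`, differs from compound 1 in one place: cyclobutylsulfanyl in place of cyclobutyloxy on a carbonyl carbon. Among the compounds with values here, no measured step alters the cyclobutyloxy on the carbonyl carbon in this way, so the one known step offers only indirect guidance: a single-atom exchange within that region moved the maximal response modestly, and a shift of similar or smaller size seems plausible here. Compound 3 is therefore expected to show a step of a number 6 percentage points lower from compound 1 to compound 3 (within the scatter). For compound 3 the estimate is 75%, with a likely range from 60% to 90%.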

Compound 3, largest response reached (reported as efficacy), in percent of the reference or control that the assay uses: 81%
Estimate against measurement, compound 3: 6 percentage points below; the measured number falls inside the stated range.
By their numbers in this assay, from the lowest: compound 2; then compounds 1 and 3 (each within the scatter of the next).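

Putting cyclobutylsulfanyl in place of cyclobutyloxy on the carbonyl carbon gives no change at the digits printed from compound 1 to compound 3 (within the scatter) in this assay and so shows that, with the cyclobutyl ring kept, this oxygen can be exchanged for sulfur without a measurable difference in maximal response. Compound 3 also shows a number 15 percentage points higher from compound 2 to compound 3 (beyond the scatter) and so stands with compound 1 and apart from compound 2, which means that among these three compounds only the oxetan-3-yl change separates the numbers. Nothing measured here explains this result.

The compounds shown leave open whether an amine or a longer chain, such as an n-butyl group, on the carbonyl carbon would keep the response. They also leave open whether sulfur would behave the same way with the oxetan-3-yl ring in place of cyclobutyl.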